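Vinyl for ethyl on the ammonium nitrogen of compound 2

The source may report more compounds than this note shows. Statements on the series, on what has been measured and on what is new or still open speak of the compounds shown alone.

Measured compounds:
- compound 1, `C[N+](C)(C)C/C=C/C(=O)[O-]`: 3800 nM
- compound 2, `CC[N+](C)(C)NCCC(=O)[O-]`: 140000 nM

Both compounds were read in an assay for inhibition of gamma-butyrobetaine dioxygenase (Homo sapiens), read by HPLC, with stated times of 15 min and 30 min; a higher number here means a weaker inhibitor, a lower number a stronger inhibitor. Compound 1 gives 3800 nM in this assay. Compound 2 gives 140000 nM in this assay, the highest of the two numbers; the gap to compound 1 is well beyond the scatter, and the two structures differ in more than one place, so no single change can be read from that pair.

The next compound, compound 3 `C=C[N+](C)(C)NCCC(=O)[O-]`, keeps the whole of compound 2 except for one change: vinyl in place of ethyl on an amine nitrogen. For the measured compounds named here, no measured pair in this small set shows the effect of such a swap, so the direction of the step is open. A step of modest size is expected, not clearly beyond the scatter in either direction, and compound 3 is expected to stay near the value of compound 2 in this assay.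

For compound 3 the expected value in this assay is 80000 nM, with a range of 20000 nM to 300000 nM. The estimated step from compound 2 to compound 3 is a 1.8-fold lower number from compound 2 to compound 3 (0.24 log units; within the scatter).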

Compound 3, half-maximal inhibitory concentration: 6800 nM
Compound 3: the middle estimate sits 12-fold (1.07 log units) above what was measured, outside the stated range (below it).
By their numbers in this assay, from the lowest: compounds 1 and 3 (each within the scatter of the next); then compound 2.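

On an amine nitrogen whose other neighbours are an amine nitrogen and two saturated chain carbons, the choice of group clearly matters in this assay: vinyl in place of ethyl gives a 21-fold lower number from compound 2 to compound 3 (1.31 log units; beyond the scatter). The two groups match in what is counted, with two carbons each, no ring, no net charge and no hydrogen-bond donors or acceptors, so the one counted difference in this pair is the double bond that vinyl brings. Nothing available explains the size of this step, and the swap remains a single observation on a single core.

Going by these compounds, whether the double bond itself is what matters stays open, since one pair cannot separate it from other differences between vinyl and ethyl, and an ethynyl, allyl or propyl group on the same nitrogen would help to test this. Also open, on these data alone, is whether vinyl in place of ethyl gives a step of similar size and direction when the carboxylate chain of the core is longer or shorter.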